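A few compounds are considered here, and "the series" means these few. Any claim that something is new, unique, unknown or untested is made for them only; others in the source may bear on it.

Measured so far:
compound 1, `O=S(=O)(c1ccc(F)c(Cl)c1)c1cnc2cc(F)ccc2c1-c1ccc(Cl)cc1` — 30 mg/kg
compound 2, `O=S(=O)(c1ccc(F)c(F)c1)c1cnc2cc(F)ccc2c1-c1ccc(Cl)cc1` — 10 mg/kg

In a functional assay on the whole organism (strain Wistar) with Rattus norvegicus as the target (on this read-out lower numbers stand for an effect already at smaller amounts and higher numbers for an effect only at larger amounts of compound), compound 1 gives 30 mg/kg, the higher of the two numbers; its nearest neighbour, compound 2, gives 10 mg/kg. Among the measured compounds shown here, the one step recorded, a 3.0-fold lower number from compound 1 to compound 2 (0.48 log units; beyond the scatter), is a modest one and came with fluoro in place of chloro on an aromatic carbon. Compound 3, `O=S(=O)(c1ccc(F)c(Cl)c1)c1cnc2cc(F)ccc2c1-c1ccc(F)cc1`, differs from compound 1 in this way: fluoro in place of chloro on an aromatic carbon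
This swap sits on the other aromatic ring of the shared core, so the recorded step bears on it only loosely. A modest lowering is expected, roughly a 2.0-fold lower number from compound 1 to compound 3 (0.30 log units; within the scatter). Compound 3 is therefore estimated at 15 mg/kg, with a range from 6 mg/kg to 40 mg/kg.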

Compound 3, minimum effective dose: 10 mg/kg
For compound 3 the middle estimate is 1.5-fold (0.18 log units) above the measured one; low and high end bracket the measured number.
By their numbers in this assay, from the lowest: compounds 2 and 3 (each within the scatter of the next); then compound 1.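

The change from 4-chlorophenyl to 4-fluorophenyl gives a 3.0-fold lower number from compound 1 to compound 3 (0.48 log units; beyond the scatter) in this assay, which shows that this position also responds to the exchange. The same exchange elsewhere on compound 1 gave a 3.0-fold lower number from compound 1 to compound 2 (0.48 log units; beyond the scatter) and is of equal size, so among these compounds the swap lowers the number at both places. Nothing available accounts for either step. From the compounds shown here alone, it remains open whether hydrogen, a methyl, a methoxy or an amine at this position would shift the number further. Going by these compounds, it also remains open whether the two fluoro exchanges would add up within one compound.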